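Two Ethylthio Groups in Place of Methoxy and Methylthio

The source may hold more compounds than are shown below. What is called first, only, known or untested is meant among the compounds shown, and "the series" means these compounds.

Compound 2 `COc1cc([C@](O)(CCN(C)C)[C@@H](c2cc3cc(C#N)ccc3nc2OC)c2cccc(OC)c2F)cc(SC)n1` has the highest number among the three compounds measured in an ADME assay on microsomes from liver (Homo sapiens) for metabolic stability (a higher number here means faster removal of the compound, a lower number slower removal), at 16 uL/min. Compound 1 `COc1cc([C@](O)(CCN(C)C)[C@@H](c2cc3cc(Br)ccc3nc2OC)c2cccc(OC)c2F)cc(SC)n1` gives 4.8 uL/min, and the step of a 3.3-fold higher number from compound 1 to compound 2 (0.52 log units; beyond the scatter) was a cyano in place of bromo on an aromatic carbon change. Going by the values given here, compound 3 `CCOc1cc([C@](O)(CCN(C)C)[C@@H](c2cc3cc(Br)ccc3nc2OC)c2ccnc(OC)c2OC)cc(OC(C)C)n1` gives 1.8 uL/min, but differs from compound 2 in several places, so no single step links them.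

Compound 4 `CCSc1cc([C@](O)(CCN(C)C)[C@@H](c2cc3cc(C#N)ccc3nc2OC)c2cccc(OC)c2F)cc(SCC)n1` differs from compound 2 by a group of 12 heavy atoms (9 carbon, 1 nitrogen, 2 sulfur; one six-membered aromatic ring with 1 hetero atom) in place of a group of 10 heavy atoms (7 carbon, 1 nitrogen, 1 oxygen, 1 sulfur; one six-membered aromatic ring with 1 hetero atom), on a saturated chain carbon bound to an oxygen on a saturated carbon and two saturated chain carbons. Among the compounds with values here, no measured step touches this part of the shared core, so nothing here predicts the direction of change with confidence. For compound 4 the expected step is a 1.4-fold higher number from compound 2 to compound 4 (0.14 log units; within the scatter), a small rise that stays close to the scatter. Compound 4 is therefore estimated at 22 uL/min, within a range of 8 uL/min to 60 uL/min.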

Compound 4, intrinsic clearance in a liver preparation (reported as CLH), per the amount of preparation that the assay uses: 17 uL/min
For compound 4 the middle estimate is 1.3-fold (0.11 log units) above the measured one; measured number inside the range.
By their numbers in this assay, from the lowest: compound 3; then compound 1; then compounds 2 and 4 (each within the scatter of the next).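

In this assay, two ethylthio groups in place of methoxy and methylthio give a 1.1-fold higher number from compound 2 to compound 4 (0.03 log units; within the scatter), so this larger group on the saturated chain carbon leaves the number indistinguishable from that of the group it replaces. The earlier compounds shown here offered no single-place step in this part of the shared core, and this step now gives a first reading there. Nothing available explains this result.

Both ring substituents differ at once, so the contribution of each remains unresolved. A single ethylthio group paired with methoxy, or an amine in either spot, would be needed to separate them.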